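Notes on the step from compound 2 to compound 3

The compounds below may be only part of what the source reports. "The series", "measured", "known", "first", "only" and "open" are said of these compounds alone.

Measured in an ADME assay on BJ cells (Homo sapiens) for cytotoxicity, with a stated time of 72 h; on this read-out lower numbers stand for an effect already at smaller amounts and higher numbers for an effect only at larger amounts of compound:
- compound 1 `Nc1nc(-c2ccccn2)nn1-c1ncnc2cc(OC(F)(F)F)ccc12`: > 13000 nM (a limit)
- compound 2 `COc1cc2ncnc(-n3nc(-c4ccccn4)nc3N)c2cc1OCc1ccccc1`: > 27000 nM (a limit)

Neither compound has a number yet in this assay. Compound 2 stands at > 27000 nM, which is a limit of the assay and not a number.

Compound 3 `COc1cc2ncnc(-n3nc(-c4ccccn4)nc3N)c2cc1OCCCNC(=O)OC(C)(C)C` is the next to be read. The change from compound 2 is 2-((tert-butoxycarbonyl)amino)ethyl in place of phenyl on a saturated chain carbon bound to an oxygen on an aromatic ring. In other words, 2-((tert-butoxycarbonyl)amino)ethyl stands in place of phenyl on a saturated chain carbon bound to an oxygen on an aromatic ring, so that benzyloxy becomes 3-((tert-butoxycarbonyl)amino)propoxy.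

Going by the values given here, no measured step gives a size for this change. A step beyond the usual scatter is not expected, and no direction is expected either. That expectation rests on compound 2 with its limit of > 27000 nM. The expected step, a step that the limit leaves unreadable from compound 2 to compound 3, is therefore small. Another reading at a limit is the likely outcome. In this assay the estimate for compound 3 is 30000 nM, with an expected range of 12000 nM to 60000 nM.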

Compound 3, half-maximal effective concentration: > 12000 nM
Compound 3 gave a limit, no number (the forecaster's own chance of this, stated with the estimate: 80%); the middle value lies beyond the limit too.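

Going by these compounds alone, compound 2 and compound 3 both stand as limits, not numbers, in this assay, so no step between them can be read. The compounds shown leave open whether any of them would give a number in this assay, and so how benzyloxy and 3-((tert-butoxycarbonyl)amino)propoxy compare there.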